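The compounds below may be only part of what the source reports. "The series", "measured", "known", "first", "only" and "open" are said of these compounds alone.

Measured in a functional assay on SW-620 cells (Homo sapiens) for cytotoxicity, read by sulforhodamine B assay, with a stated time of 48 h; on this read-out higher numbers stand for weaker inhibition and lower numbers for stronger inhibition:
- compound 1 `C[C@H]1CC[C@@H]2[C@@H](OC(=O)[C@]23CC(c2ccccc2[N+](=O)[O-])=NO3)[C@]2(C)C(=O)C=C[C@@]12O`: 40000 nM
- compound 2 `COc1ccc(C2=NO[C@]3(C2)C(=O)O[C@@H]2[C@H]3CC[C@H](C)[C@]3(O)C=CC(=O)[C@@]23C)cc1OC`: 86000 nM
- compound 3 `C[C@H]1CC[C@@H]2[C@@H](OC(=O)[C@]23CC(c2ccc(F)cc2)=NO3)[C@]2(C)C(=O)C=C[C@@]12O`: 3600 nM

Compound 3 has the lowest number of the three, and its steps to both others lie beyond the scatter. Compound 4 `C[C@H]1CC[C@@H]2[C@@H](OC(=O)[C@]23CC(c2ccc(C#N)cc2)=NO3)[C@]2(C)C(=O)C=C[C@@]12O` keeps the shared core and has cyano in place of fluoro on an aromatic carbon, para to a large group (cyano in place of fluoro on an aromatic carbon). The nearest evidence comes from two other changes at this group: an 11-fold lower number from compound 1 to compound 3 (1.05 log units; beyond the scatter) and a 24-fold lower number from compound 2 to compound 3 (1.38 log units; beyond the scatter), both large. Among the measured compounds shown here, neither measured replacement of 4-fluorophenyl matched compound 3, but no measured compound carries cyano. In this assay, a higher number is therefore expected, probably by less than those steps, and the estimated step is a 2.5-fold higher number from compound 3 to compound 4 (0.40 log units; beyond the scatter). The estimate for compound 4 is 9000 nM, with an expected range of 2500 nM to 35000 nM.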

Compound 4, half-maximal inhibitory concentration in the SW-620 assay: 53000 nM
Compound 4: the middle estimate sits 5.9-fold (0.77 log units) below what was measured; measured number outside the range, above it.
By their numbers in the SW-620 assay, from the lowest: compound 3; then compounds 1, 4 and 2 (each within the scatter of the next, the first and the last beyond it).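

In the SW-620 assay, this position proves sensitive to exchanging one small group for another, with a 15-fold higher number from compound 3 to compound 4 (1.17 log units; beyond the scatter). Compound 4 sits level with the other two, with a 1.6-fold lower number from compound 2 to compound 4 (0.21 log units; within the scatter) and a 1.3-fold higher number from compound 1 to compound 4 (0.12 log units; within the scatter), so among these four only compound 3, with fluoro, stands apart. In a physicochemical assay for lipophilicity (a lower number here means a more polar compound, a higher number a more lipophilic compound), compound 3 gives 1.58 and compound 4 gives 1.17 so the same exchange gives a more polar compound: the measured partition coefficient of compound 3, 1.58, and of compound 4, 1.17, a number 0.41 log units lower (beyond the scatter)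

A single pair cannot tell whether that shift in polarity is linked to the loss of cell activity. A chloro or methyl group on the same aromatic carbon would show whether the 4-fluorophenyl result is special to fluoro.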